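The compounds below may be only part of what the source reports. "The series", "measured", "known", "first", "only" and "open" are said of these compounds alone.

Measured so far in an ADME assay on HepG2 cells (Homo sapiens) for cytotoxicity, read by MTT assay, with a stated time of 24 h; on this read-out lower numbers stand for higher toxicity in this test and higher numbers for lower toxicity in this test:
- Compound 1 `Cc1ccc(C#Cc2c([N+](=O)[O-])nc3n2CC(C)O3)cc1`: 4440 nM
- Compound 2 `CC1Cn2c(nc([N+](=O)[O-])c2C#CC2CC2)O1`: 14800 nM

Compound 1 has the lower of these two numbers, and so shows the higher toxicity in this assay. Compound 3 `CC1Cn2c(nc([N+](=O)[O-])c2C#Cc2ccc(C(C)(C)C)cc2)O1` keeps the core of compound 1 and makes one change: tert-butyl in place of methyl on an aromatic carbon. Among the measured compounds shown here, only one measured step bears on this, and only loosely: a 3.3-fold higher number from compound 1 to compound 2 (0.52 log units; beyond the scatter). For the measured compounds named here, that step removes the whole 4-methylphenyl, whereas compound 3 keeps the aromatic ring, so no comparable step can be assumed. The expected result is no change beyond the scatter, with a 1.1-fold lower number from compound 1 to compound 3 (0.05 log units; within the scatter) as the estimated step. The estimate for compound 3 is 4000 nM, with an expected range of 1500 nM to 11000 nM.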

Compound 3, half-maximal cytotoxic concentration: 4220 nM
Compound 3: the middle estimate sits 1.1-fold (0.02 log units) below what was measured; the measured number falls inside the stated range.
By their numbers in this assay, from the lowest: compounds 3 and 1 (each within the scatter of the next); then compound 2.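

In this assay, enlarging methyl to tert-butyl on this aromatic carbon gives a 1.1-fold lower number from compound 1 to compound 3 (0.02 log units; within the scatter), so this position takes a much larger carbon group with no change beyond the scatter. Compound 2 had shown only what happens when the whole 4-methylphenyl is replaced; compound 3 adds that, with the aromatic ring kept, the size of this hydrocarbon group does not shift the number. Nothing available explains this result.

From the compounds shown here alone, whether an amine or a carboxylic acid at this position would leave the number equally unchanged stays open. So does the effect of a halogen such as fluorine or chlorine there.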